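The source may report more compounds than this note shows. Statements on the series, on what has been measured and on what is new or still open speak of the compounds shown alone.

Compound 1 `Cc1cccc(Cn2cc(CNC(=O)c3cnc(Nc4ccc(C#N)cc4)cc3Oc3c(C)cc(C)cc3C)nn2)c1`: 114000 nM
Compound 2 `CCOC(=O)Cn1cc(CNC(=O)c2cnc(Nc3ccc(C#N)cc3)cc2Oc2c(C)cc(C)cc2C)nn1`: 9530 nM
Compound 3 `Cc1cc(C)c(Oc2cc(Nc3ccc(C#N)cc3)ncc2C(=O)NCc2cn(Cc3ccccc3C#N)nn2)c(C)c1`: > 219000 nM

Within the data shown here, in an ADME assay on MT4 cells (Homo sapiens) for cytotoxicity, read by MTT assay, with a stated time of 5 days (on this read-out lower numbers stand for higher toxicity in this test and higher numbers for lower toxicity in this test), compound 3 reached only the limit of the test (the limit of > 219000 nM in this assay, at which 1 of the 3 values shown sits), so its true number is not known; it is the one compound of the three whose value is a limit rather than a number. Compound 4 `Cc1cc(C)c(Oc2cc(Nc3ccc(C#N)cc3)ncc2C(=O)NCc2cn(CC(N)=O)nn2)c(C)c1` differs from compound 3 in one place: carbamoyl in place of 2-cyanophenyl on a saturated chain carbon bound to an aromatic nitrogen. Among the measured compounds shown here, two measured steps bear on this. The step of a 12-fold lower number from compound 1 to compound 2 (1.08 log units; beyond the scatter) shows that exchanging an aromatic ring for a small chain group on that carbon gave a markedly lower number, and the step of an at least 22-fold higher number from compound 2 to compound 3 (1.36 log units; beyond the scatter) shows the reverse exchange giving a markedly higher one. The carbamoyl of compound 4 is, like the ethoxycarbonyl of compound 2, a small chain group without a ring, so a lower number is expected from compound 3 to compound 4, namely an at least 7.3-fold lower number from compound 3 to compound 4 (0.86 log units; beyond the scatter), though the starting limit makes its size uncertain. In this assay compound 4 is expected to give about 30000 nM, within a range from 8000 nM to 200000 nM.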

Compound 4, half-maximal cytotoxic concentration: 24000 nM
For compound 4 the middle estimate is 1.3-fold (0.10 log units) above the measured one; measured number inside the range.
By their numbers in this assay, from the lowest: compound 2; then compound 4; then compound 1. At a limit, above all of these: compound 3.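

On the saturated chain carbon bound to an aromatic nitrogen, carbamoyl now shows that the drop seen with ethoxycarbonyl is not confined to that one small group without a ring. In this assay there is a 4.8-fold lower number from compound 1 to compound 4 (0.68 log units; beyond the scatter), and also an at least 9.1-fold lower number from compound 3 to compound 4 (0.96 log units; beyond the scatter). Compound 3 stands at a limit, not at a number, so that second step gives only a floor: the limit of > 219000 nM in this assay, at which 1 of the 4 values shown sits. The small groups also differ from each other, since amino in place of ethoxy on a carbonyl carbon gives a 2.5-fold higher number from compound 2 to compound 4 (0.40 log units; beyond the scatter).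

On these data alone, whether the aromatic ring or simply the size of the group goes with the higher numbers stays open. A longer chain ending in carbamoyl, or a carboxylic acid or an amine on that carbon, would test how far the trend holds.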